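Pyrazinyl for pyridinyl on the piperazine of compound 2

The compounds below may be only part of what the source reports. "The series", "measured", "known", "first", "only" and "open" are said of these compounds alone.

The measured compounds, with their values in a functional assay on HeLa cells (Homo sapiens) for antiproliferative activity, read by CCK-8 assay, with a stated time of 72 h, tested at 8 uM; on this read-out higher numbers stand for a stronger effect at the one concentration tested and lower numbers for a weaker effect:
Compound 1, `CC1CCCCN1C(=S)SCc1ccc(C(=O)Nc2ccccc2N)cc1`, gives 76.3%.
Compound 2, `Nc1ccccc1NC(=O)c1ccc(CSC(=S)N2CCN(c3ccncc3)CC2)cc1`, gives 77.4%.
Compound 3, `Nc1ccccc1NC(=O)c1ccc(CSC(=S)N2CCc3cc(Cl)ccc32)cc1`, gives 65.1%.

Compound 2 has the highest of the three numbers in this assay, but its value and that of compound 1 lie within the scatter of each other, so the two cannot be ranked; only compound 3 stands clearly lower. For the measured compounds named here, the one change recorded on this core is the step of a number 11.2 percentage points lower from compound 1 to compound 3 (beyond the scatter), which sits on the thiocarbonyl nitrogen.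

The new compound 4, `Nc1ccccc1NC(=O)c1ccc(CSC(=S)N2CCN(c3cnccn3)CC2)cc1`, differs from compound 2 in the change (pyrazin-2-yl in place of pyridin-4-yl on an amine nitrogen in a ring). Going by the values given here, this change is at the amine nitrogen of the six-membered ring, a different place from the one the step from compound 1 to compound 3 probes, so no measured step bears directly on it. Among the compounds with values here, the data hold no example of one six-membered aromatic ring being swapped for another at this position. The step is therefore expected to fall within the scatter, with no direction claimed: a number 2.4 percentage points lower from compound 2 to compound 4 (within the scatter). Compound 4 is expected to give about 75%, between 62% and 86%.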

Compound 4, a percentage reported as inhibition, at one concentration (the size of the read-out at that concentration, not a potency): 76.9%
For compound 4 the middle estimate is 1.9 percentage points below the measured one; measured number inside the range.
By their numbers in this assay, from the lowest: compound 3; then compounds 1, 4 and 2 (each within the scatter of the next).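

In this assay, for the compounds shown here, the change reads as a number 0.5 percentage points lower from compound 2 to compound 4 (within the scatter) and gives the first one-place comparison on an amine nitrogen in a ring; the earlier step between compound 1 and compound 3 lay on the thiocarbonyl side and said nothing about this place. It shows that, on this read-out and at the one concentration tested, a six-membered aromatic ring with 2 hetero atoms can stand in for one with 1 hetero atom without a difference that can be told from the scatter. Going by these compounds alone, the pair thus shows that pyridin-4-yl is not the only aromatic group on this nitrogen compatible with a high reading, although no information given here bears on the reason for this result.

The compounds shown leave open whether the same holds for a group of another kind on this nitrogen, such as phenyl, a methyl group or an acetyl group. They also leave open whether compound 2 and compound 4 would still read alike over a range of concentrations or on cells other than HeLa.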